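The source may hold more compounds than are shown below. What is called first, only, known or untested is meant among the compounds shown, and "the series" means these compounds.

Compound 1: `CN1CCN(C(=O)CCSc2nc3cc(Cl)ccc3o2)CC1` — 41.5 mL/min/g
Compound 2: `CC1CCN(C(=O)CCSc2nc3cc(Cl)ccc3o2)C1` — 90.7 mL/min/g
Compound 3: `CN(C)C(=O)CCSc1nc2cc(Cl)ccc2o1` — 41.8 mL/min/g

These three compounds share a core and differ only in the amine attached to the carbonyl carbon. In an ADME assay on microsomes from liver (Mus musculus) for metabolic stability, read by LC-MS, using NADPH, with a stated time of 45 min, tested at 0.5 uM (on this read-out lower numbers stand for slow clearance and higher numbers for fast clearance), compound 3 gives 41.8 mL/min/g, the second highest of the three numbers; compound 1 gives 41.5 mL/min/g, a number that cannot be told apart from it within the scatter, while compound 2 gives 90.7 mL/min/g, a clearly higher number.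

Compound 4 is `CC1CCCN1C(=O)CCSc1nc2cc(Cl)ccc2o1`, not yet measured. It differs from compound 3 in one place: 2-methylpyrrolidin-1-yl in place of dimethylamino on a carbonyl carbon

The measured steps that bear on this change both involve a methylpyrrolidinyl ring taking the place of a smaller or different amine on the same carbonyl carbon. The step of a 2.2-fold higher number from compound 1 to compound 2 (0.34 log units; beyond the scatter) and the step of a 2.2-fold lower number from compound 2 to compound 3 (0.34 log units; beyond the scatter) both show that the compound carrying the 3-methylpyrrolidin-1-yl ring sits at the higher number. Since compound 4 carries a closely related 2-methylpyrrolidin-1-yl ring in the same place, a modest rise in this assay is expected, in the direction of faster clearance, with an expected step of a 1.9-fold higher number from compound 3 to compound 4 (0.28 log units; within the scatter). The value expected for compound 4 is 80 mL/min/g, most likely between 40 mL/min/g and 160 mL/min/g.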

Compound 4, intrinsic clearance in a liver preparation (reported as CLH), per the amount of preparation that the assay uses: 98 mL/min/g
Estimate against measurement, compound 4: 1.2-fold (0.09 log units) below; measured number inside the range.
By their numbers in this assay, from the lowest: compounds 1 and 3 (each within the scatter of the next); then compounds 2 and 4 (each within the scatter of the next).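

Going by these compounds alone, until now, only one methyl-bearing pyrrolidine ring had been seen on this carbonyl carbon; the 2-methylpyrrolidin-1-yl ring shows that the high number in this assay is not tied to the 3-methylpyrrolidin-1-yl ring alone. Exchanging one ring for the other gives a 1.1-fold higher number from compound 2 to compound 4 (0.03 log units; within the scatter), so the two rings cannot be told apart here. Against the other two amines, the new ring gives a 2.3-fold higher number from compound 3 to compound 4 (0.37 log units; beyond the scatter) and a 2.4-fold higher number from compound 1 to compound 4 (0.37 log units; beyond the scatter), so among these four compounds both methylpyrrolidine rings stand clear of dimethylamino and 4-methylpiperazin-1-yl, with no compound going against this.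

Nothing measured here explains why these amines differ in clearance. As far as these compounds go, whether the ring itself or its methyl goes with the higher number stays open, and a plain pyrrolidin-1-yl ring without a methyl on this carbonyl carbon would bear directly on that.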